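A few compounds are considered here, and "the series" means these few. Any claim that something is new, unique, unknown or untested is made for them only; others in the source may bear on it.

Among the measured compounds shown here, compound 1, with the structure `Fc1ccc2nc(-c3ccccc3)nc(Nc3ccccc3)c2c1`, is one of two compounds measured in a functional assay on COLO 205 cells (Homo sapiens) for cytotoxicity, read by MTT assay, with a stated time of 48 h; a higher number here means a weaker inhibitor, a lower number a stronger inhibitor. In this assay compound 1 gives > 50000 nM, which is a limit of the assay and not a number. Compound 2, with the structure `Fc1cccc(-c2nc(Nc3ccc(Cl)cc3)c3cc(F)ccc3n2)c1`, is the other; in this assay compound 2 gives 32600 nM. For the measured compounds named here, compound 2 therefore stands as the only compound here with a number of its own, the other reading being (the limit of > 50000 nM in this assay, at which 1 of the 2 values shown sits).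

Compound 3, with the structure `Oc1cccc(Nc2nc(-c3cccc(F)c3)nc3ccc(F)cc23)c1`, has not yet been measured. It differs from compound 2 in one place: 3-hydroxyphenyl in place of 4-chlorophenyl on a nitrogen on an aromatic ring, which, read one bond further out, is (4-chlorophenyl)amino to (3-hydroxyphenyl)amino. Going by the values given here, no step between measured compounds is available to guide this change, so the direction rests on the two readings alone, both of them weak. Compound 3 is expected to stay in the same weak region, with a step of about a 1.3-fold lower number from compound 2 to compound 3 (0.12 log units; within the scatter) that may well lie within the scatter. For compound 3 the estimate in this assay is 25000 nM, from 6000 nM to 80000 nM.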

Compound 3, half-maximal inhibitory concentration: > 50000 nM
Compound 3: only a limit was reported; the forecaster's own chance of this, stated with the estimate: 30%; middle value at least 2.0-fold (0.30 log units) away from the limit.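

At this position, on a nitrogen on an aromatic ring, putting 3-hydroxyphenyl in place of 4-chlorophenyl gives in this assay an at least 1.5-fold higher number from compound 2 to compound 3 (0.18 log units; that floor lies within the scatter). Compound 3 gives only a limit of the assay and not a number, so the step has a floor but no known size, and that floor does not separate the two compounds beyond the usual scatter. What the change does show is that a ring carrying a hydroxyl on this nitrogen brought no reading under the limit, which now holds most of the readings: the limit of > 50000 nM in this assay, at which 2 of the 3 values shown sit.

The compounds shown leave open whether any group on this nitrogen can give a number clearly lower than that of compound 2, for instance a phenyl ring carrying an amine, a carboxylic acid or a methoxy group. They also leave open whether 3-hydroxyphenyl would read the same way if the fluorine atoms on the rest of the structure were replaced by chlorine or by a methyl group.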